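Hydroxy in Place of Chloro on the Shared Core

The source may hold more compounds than are shown below. What is called first, only, known or untested is meant among the compounds shown, and "the series" means these compounds.

Compound 1, `COc1ccc(/C=C2\NS(=O)(=O)c3ccccc3C2=O)cc1`, in an assay for inhibition of Intestinal-type alkaline phosphatase (Homo sapiens), read by spectrophotometry, with stated times of 10 min and 20 min; a higher number here means a weaker inhibitor, a lower number a stronger inhibitor: 1530 nM
Compound 2, `O=C1/C(=C/c2ccc(Br)cc2)NS(=O)(=O)c2ccccc21`, in this assay: 3690 nM
Compound 3, `O=C1/C(=C/c2cccc(Cl)c2)NS(=O)(=O)c2ccccc21`, in this assay: 3770 nM

Compound 3 holds the highest of the three numbers, though only narrowly: the step of a 1.0-fold higher number from compound 2 to compound 3 (0.01 log units; within the scatter) lies within the scatter, so the two halogen-bearing compounds cannot be told apart. Compound 1 stands clearly lower, the step of a 2.4-fold higher number from compound 1 to compound 2 (0.38 log units; beyond the scatter) being the only one beyond the scatter in this small set.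

Compound 4, `O=C1/C(=C/c2cccc(O)c2)NS(=O)(=O)c2ccccc21`, differs from compound 3 in one place: hydroxy in place of chloro on an aromatic carbon. The step that bears most on this change is the exchange of methoxy for bromo, a 2.4-fold higher number from compound 1 to compound 2 (0.38 log units; beyond the scatter), where replacing an oxygen-bearing group by a halogen raised the number by a modest amount. Read in reverse, it suggests that putting an oxygen-bearing group back in place of a halogen should lower the number again. Hydroxy is not methoxy, however, and the 3-hydroxyphenyl of compound 4 carries its group at a different ring position than the methoxy of compound 1, so the expectation is loose. Compound 4 is therefore expected to give a modestly lower number, a 1.6-fold lower number from compound 3 to compound 4 (0.20 log units; within the scatter), with an estimate of 2400 nM and a range from 900 nM to 6500 nM.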

Compound 4, half-maximal inhibitory concentration: 1210 nM
Compound 4: middle estimate off by 2.0-fold (0.30 log units), on the high side, within the range that was stated.
By their numbers in this assay, from the lowest: compounds 4 and 1 (each within the scatter of the next); then compounds 2 and 3 (each within the scatter of the next).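

In this assay, the exchange of chloro for hydroxy, with the ring place held fixed, meta to a large group, gives a 3.1-fold lower number from compound 3 to compound 4 (0.49 log units; beyond the scatter); this isolates the effect of the group at this position, which the earlier step between compounds with different groups and ring places could not do. Measured against the 4-bromophenyl compound, the change to 3-hydroxyphenyl gives a 3.0-fold lower number from compound 2 to compound 4 (0.48 log units; beyond the scatter), a step of much the same size, so with either halogen-bearing compound as the starting point hydroxy gives a lower number beyond the scatter. Nothing measured here accounts for the lower number given by hydroxy at this position.

The compounds shown leave open whether this lower number is particular to hydroxy or would also appear with methoxy, an amine or a carboxylic acid on the same aromatic carbon. They also leave open whether hydroxy would give a similar step on the ring carbon that carries the bromo in compound 2.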